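Swapping benzyl for 4-nitrophenyl on the shared triazole

The compounds below may be only part of what the source reports. "The series", "measured", "known", "first", "only" and "open" are said of these compounds alone.

This account follows a pair of measured compounds and one that is still to be tested. Compound 1 `O=C1NC(=O)/C(=C/c2ccc(OCc3csc(-c4ccccc4)n3)cc2)S1` and compound 2 `O=C1NC(=O)/C(=C/c2ccc(OCCSc3nnc(Cc4ccccc4)[nH]3)cc2)S1` share the same core and differ in the arm attached to the ether oxygen. In a functional assay on the whole organism (strain Wistar) with Rattus norvegicus as the target, with a stated time of 15 days, at a dose of 30 mg/kg by the oral route (on this read-out higher numbers stand for a stronger effect at the one dose given and lower numbers for a weaker effect), compound 1 gives 40.3%, and in this assay compound 2 gives 38.3%. Of the two numbers compound 2 holds the lower one, but its gap to compound 1 lies within the scatter, so the two cannot be ordered.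

Compound 3 `O=C1NC(=O)/C(=C/c2ccc(OCCSc3nnc(-c4ccc([N+](=O)[O-])cc4)[nH]3)cc2)S1` keeps the whole of compound 2 except for one group: 4-nitrophenyl in place of benzyl on an aromatic carbon. For the measured compounds named here, no measured pair shows the effect of this change, so no step can be read from the data. With only compound 2 as a foothold, the author expects the step of a number 0.3 percentage points lower from compound 2 to compound 3 (within the scatter) to stay within the scatter, in no firm direction. Compound 3 is therefore estimated at 38%, with a range from 20% to 56%.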

Compound 3, a percentage reported as activity, at one dose (the size of the read-out at that dose, not a potency): 18.6%
Compound 3: middle estimate off by 19.4 percentage points, on the high side; the measured number lies below the stated range.
By their numbers in this assay, from the lowest: compound 3; then compounds 2 and 1 (each within the scatter of the next).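

In this assay, for the compounds shown here, the aromatic carbon of the five-membered aromatic ring with 3 nitrogen proves sensitive to the group it carries: 4-nitrophenyl in place of benzyl gives a number 19.7 percentage points lower from compound 2 to compound 3 (beyond the scatter), the only step that can be read at this position. Both groups bring one six-membered aromatic ring of carbon only, so keeping such a ring here does not by itself preserve the read-out, and the step comes with a swap that also adds one nitrogen and two oxygen atoms and 2 hydrogen-bond acceptors. No measurement among these compounds accounts for the step, so its origin remains unexplained.

The swap alters two features in a single step, so the compounds shown cannot separate the nitro group from the loss of the benzyl carbon that sets the ring apart from the core. On these data alone, whether a plain phenyl would stay close to compound 2, and whether a 4-aminophenyl or a 4-carboxyphenyl would follow compound 3 or compound 2, remains open, as does whether the step would hold at other doses.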